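Working notes: compound 2 to compound 3

This account rests on a few compounds, and the source may have more. Where it says the series, first, only, none or still open, it means among the compounds named here.

Measured in a functional assay on NCI-H3122 cells (Homo sapiens) for antiproliferative activity, read by MTT assay, with a stated time of 48 h; a lower number here means a stronger inhibitor, a higher number a weaker inhibitor:
- compound 1 `Cc1ccc(CNC(=O)c2cccc(C(C)Oc3cccnc3Nc3nccs3)c2)cc1` gives 15300 nM
- compound 2 `COc1cccc(CNC(=O)c2cccc(C(C)Oc3ccnc(Nc4cnn(C)c4)c3)c2)c1` gives > 100000 nM

Compound 2 stands only as a limit of this assay (> 100000 nM), not as a number.

Compound 3 `COc1cc(CNC(=O)c2cccc(C(C)Oc3ccnc(Nc4cnn(C)c4)c3)c2)cc(OC)c1OC` carries 3,4,5-trimethoxyphenyl in place of 3-methoxyphenyl on a saturated chain carbon bound to an amide-type nitrogen. Among the measured compounds shown here, no measured pair differs in one place, so the size of this change rests on no direct precedent. A small step toward stronger inhibition is expected, possibly none beyond the scatter. For the measured compounds named here, the only numerical reading is compound 1 (15300 nM), so the expectation stays in the weak range. The expected change is an at least 1.1-fold lower number from compound 2 to compound 3 (0.04 log units; that floor lies within the scatter) ( estimated ). For compound 3 the estimated value is 90000 nM ( expected range 30000 nM to 200000 nM).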

Compound 3, half-maximal inhibitory concentration: 29000 nM
Estimate against measurement, compound 3: 3.1-fold (0.49 log units) above; measured number below the stated range.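

In this assay, the place on a saturated chain carbon bound to an amide-type nitrogen proves able to move the read-out: 3,4,5-trimethoxyphenyl in place of 3-methoxyphenyl gives an at least 3.4-fold lower number from compound 2 to compound 3 (0.53 log units; beyond the scatter). With compound 3 at 29000 nM, the core shared by compound 2 and compound 3 now has a readable number in this assay. The step is a floor and not a full size, because compound 2 stands only at a limit of the assay: the limit of > 100000 nM in this assay, at which 1 of the 3 values shown sits.

On these data alone, whether the step belongs to 3,4,5-trimethoxyphenyl as a whole or to one of its methoxy groups stays open, as does the outcome with an amine or a carboxylic acid in the same place. Compound 1 differs from compound 3 in more than one place and offers no direct comparison.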